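The source may hold more compounds than are shown below. What is called first, only, known or untested is meant among the compounds shown, and "the series" means these compounds.

Three related compounds have been measured so far in a physicochemical assay for lipophilicity, at pH 7.4 (on this read-out lower numbers stand for lower lipophilicity and higher numbers for higher lipophilicity), a read-out that shows how strongly a compound favours a fatty environment over water. In this assay, compound 2 `O=C(Nc1ccc2[nH]c(=O)[nH]c2c1)[C@H]1CCCN1C(=O)C1(c2cccc(Cl)c2)CCCC1` gives 4.4. Compound 1 `O=C(Nc1ccc2[nH]ncc2n1)[C@H]1COCCN1C(=O)C1(c2ccc(Cl)cc2)CC(F)(F)C1` gives 4.5, and compound 3 `O=C(Nc1ccc2[nH]ncc2n1)[C@H]1CCCN1C(=O)C1(c2ccc(Cl)cc2)CCC1` gives 4.7. Both of these values lie within the usual scatter of compound 2, so the three numbers cannot be told apart with confidence.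

Compound 4 `O=C(Nc1ccc2[nH]ncc2c1)[C@H]1CCCN1C(=O)C1(c2cccc(Cl)c2)CCCC1` differs from compound 2 in one place, on an amide-type nitrogen: a group of 9 heavy atoms (7 carbon, 2 nitrogen; one five-membered aromatic ring with 2 hetero atoms, one six-membered aromatic ring of carbon only) in place of a group of 10 heavy atoms (7 carbon, 2 nitrogen, 1 oxygen; one five-membered aromatic ring with 2 hetero atoms, one six-membered aromatic ring of carbon only), on an amide-type nitrogen. The group that enters is 1H-indazol-5-yl, and the rest of the structure stays the same.

Among the measured compounds shown here, no two measured compounds differ in only one place, so the data offer no direct guide to the size of this step. A modest upward move in this assay is expected, and the estimated step is a number 0.40 log units higher from compound 2 to compound 4 (beyond the scatter). This expectation is uncertain, and the range is kept wide. For compound 4 the expected value is 4.8, with an estimated range from 4.3 to 5.3.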

Compound 4, distribution coefficient: 5.4
Beside the measured number, compound 4's estimate is 0.60 log units below it; measured number outside the range, above it.
By their numbers in this assay, from the lowest: compounds 2, 1 and 3 (each within the scatter of the next); then compound 4.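

In this assay, among the compounds shown here, the group on the amide-type nitrogen proves able to shift the read-out on its own: with the rest of the structure unchanged, placing 1H-indazol-5-yl there gives a number 1.00 log units higher from compound 2 to compound 4 (beyond the scatter) and so provides the first step in this set that can be read at a single place. The two groups are close in size, and the entering group has 1 hydrogen-bond donor where the leaving group has 2, so a small change in atoms can go with a clear change in this number. No measurement here explains why the number moves.

This single step cannot show which feature of the leaving group matters. It also leaves open how a plain phenyl ring or a pyridine ring at this amide-type nitrogen would compare, and whether the step would hold on a different core.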